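This account rests on a few compounds, and the source may have more. Where it says the series, first, only, none or still open, it means among the compounds named here.

Of the compounds shown here, three built on one shared core have been tested in a functional assay on A549 cells (Homo sapiens) for antiproliferative activity, read by MTT assay, with a stated time of 48 h; on this read-out lower numbers stand for stronger inhibition and higher numbers for weaker inhibition. Compound 1 `O=c1cc(-n2cc(COc3ccccc3)nn2)c2cc(Br)ccc2o1` gives 12300 nM, compound 2 `COC(=O)c1ccccc1OCc1cn(-c2cc(=O)oc3ccc(Br)cc23)nn1` gives 5250 nM, and compound 3 `O=c1cc(-n2cc(COc3ccccc3Br)nn2)c2cc(Br)ccc2o1` gives 8430 nM. Compound 3 stands second highest of the three numbers; the gaps to the others, a 1.5-fold lower number from compound 1 to compound 3 (0.16 log units; within the scatter) and a 1.6-fold higher number from compound 2 to compound 3 (0.21 log units; within the scatter), both lie within the scatter. Compound 4 `O=c1cc(-n2cc(COc3ccccc3O)nn2)c2cc(Br)ccc2o1` differs from compound 3 by hydroxy in place of bromo on an aromatic carbon. Among the measured compounds shown here, only one measured step concerns this ring carbon, a 1.5-fold lower number from compound 1 to compound 3 (0.16 log units; within the scatter), and it stayed within the scatter; no measured step introduces a hydroxy group. A change of no more than the scatter is therefore expected in this assay. Compound 4 is expected to give 10000 nM, within a range from 4000 nM to 25000 nM. For compound 4 this estimate means a 1.2-fold higher number from compound 3 to compound 4 (0.07 log units; within the scatter).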

Compound 4, half-maximal inhibitory concentration: 7940 nM
The estimate for compound 4 lay 1.3-fold (0.10 log units) above the measured number; low and high end bracket the measured number.
By their numbers in this assay, from the lowest: compounds 2, 4, 3 and 1 (each within the scatter of the next, the first and the last beyond it).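

In this assay, putting hydroxy in place of bromo at this ring carbon, ortho to a large group, adds a hydrogen-bond donor yet leaves the number within the scatter (a 1.1-fold lower number from compound 3 to compound 4 (0.03 log units; within the scatter)). The two other steps to compound 4 also stay within it (a 1.5-fold higher number from compound 2 to compound 4 (0.18 log units; within the scatter); a 1.5-fold lower number from compound 1 to compound 4 (0.19 log units; within the scatter)), so hydroxy cannot be told apart from hydrogen, bromo or methoxycarbonyl here. Nothing available explains this result. As far as these compounds go, whether an amine or a carboxylic acid at this carbon would move the number stays open.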